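The source may hold more compounds than are shown below. What is called first, only, known or untested is meant among the compounds shown, and "the series" means these compounds.

Among the measured compounds shown here, in a functional assay (aorta) for inhibition, with Rattus norvegicus as the target (on this read-out higher numbers stand for weaker inhibition and lower numbers for stronger inhibition), three related compounds have values so far. Compound 1 `Nc1nsc(-c2ccc(N3CCN(c4cccc(C(F)(F)F)c4)CC3)nn2)n1` gives 20 nM in this assay. Compound 2 `Cc1nsc(-c2ccc(N3CCN(c4cccc(F)c4)CC3)nn2)n1` gives 6 nM and so holds the lower of the two actual numbers, with compound 1 as its nearest neighbour, higher by a margin beyond the scatter. Compound 3 `Cc1nsc(-c2ccc(N3CCN(c4cc(C(F)(F)F)cc(C(F)(F)F)c4)CC3)nn2)n1` is reported as < 0.1 nM and that value is a limit of the assay, not a number.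

Compound 4 `Cc1nsc(-c2ccc(N3CCN(c4cc(Cl)cc(Cl)c4)CC3)nn2)n1` has yet to be measured. It departs from compound 2 in one place, with 3,5-dichlorophenyl in place of 3-fluorophenyl on an amine nitrogen in a ring and the rest of the structure unchanged. For the measured compounds named here, no measured pair isolates this change, so the step can only be judged indirectly. Going by the values given here, the one guide is compound 3, which also carries two groups on that phenyl and whose reading of < 0.1 nM is again a limit. On that ground a fall in the number beyond the scatter is expected in this assay and this would mean stronger inhibition. Expressed as a step the estimate reads a 10-fold lower number from compound 2 to compound 4 (1.00 log units; beyond the scatter) and remains an expectation. For compound 4 the expected value is 0.6 nM with an estimated range from 0.08 nM to 5 nM still to be tested.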

Compound 4, half-maximal inhibitory concentration: < 0.1 nM
Compound 4 was reported as a limit; the forecaster's own chance of this, stated with the estimate: 20%; middle value at least 6.0-fold (0.77 log units) from the limit.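

In this assay, 3,5-dichlorophenyl in place of 3-fluorophenyl on an amine nitrogen in a ring brings an at least 60-fold lower number from compound 2 to compound 4 (1.77 log units; beyond the scatter), the first step among these compounds that isolates a change at this position, and a large one. It shows that, with the rest of the structure unchanged, the choice of group on this nitrogen alone moves the read-out well beyond the scatter, towards stronger inhibition. The full size of the step cannot be given because the reading for compound 4 is a limit of the assay and not a number: the limit of < 0.1 nM in this assay, at which 2 of the 4 values shown sit.

Among the compounds shown here, compound 3 and compound 4 both stand at that limit, so no step between them can be read and the order of 3,5-dichlorophenyl and the phenyl with two trifluoromethyl groups stays open. The compounds shown also leave open whether 3-chlorophenyl, with a single chlorine, would account for the step, and how a phenyl carrying methoxy groups or an amine would read at this position.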